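Phenyl for 1-methylethenyl: expected tolerance of compound 4

The source may report more compounds than this note shows. Statements on the series, on what has been measured and on what is new or still open speak of the compounds shown alone.

Compound 1 `COC(=O)CC(=O)NC1=CS(=O)(=O)O[C@@]12[C@@H](CO[Si](C)(C)C(C)(C)C)O[C@@H](n1cc(C)c(=O)n(C)c1=O)[C@@H]2O[Si](C)(C)C(C)(C)C` gives 11900 nM in a functional assay on MT4 cells (Homo sapiens); a higher number here means that more compound is tolerated, a lower number that less compound is tolerated.
Compound 2 `Cc1cn([C@@H]2O[C@H](CO[Si](C)(C)C(C)(C)C)[C@@]3(OS(=O)(=O)C=C3NCCC(=O)O)[C@H]2O[Si](C)(C)C(C)(C)C)c(=O)n(C)c1=O` gives 11500 nM.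
Compound 3 `C=C(C)C(=O)NC(=O)NC1=CS(=O)(=O)O[C@@]12[C@@H](CO[Si](C)(C)C(C)(C)C)O[C@@H](n1cc(C)c(=O)n(C)c1=O)[C@@H]2O[Si](C)(C)C(C)(C)C` gives 1190 nM.

Compound 3 stands lowest of the three: the step of a 10-fold lower number from compound 1 to compound 3 (1.00 log units; beyond the scatter) and the step of a 9.7-fold lower number from compound 2 to compound 3 (0.99 log units; beyond the scatter) both set it well apart, so less of it is tolerated than of the other two. Compound 4 `Cc1cn([C@@H]2O[C@H](CO[Si](C)(C)C(C)(C)C)[C@@]3(OS(=O)(=O)C=C3NC(=O)NC(=O)c3ccccc3)[C@H]2O[Si](C)(C)C(C)(C)C)c(=O)n(C)c1=O` differs from compound 3 in one place: phenyl in place of 1-methylethenyl on a carbonyl carbon. For the measured compounds named here, no measured step swaps one group for another on this carbonyl carbon; the two steps ending at compound 3 record the arrival of the whole ((1-methylethenyl)carbonyl)carbamoyl group, not a change inside it. The data therefore give little guidance, and a step near the scatter is expected, in either direction. Compound 4 is estimated at 1500 nM, between 500 nM and 5000 nM, meaning an expected step of a 1.3-fold higher number from compound 3 to compound 4 (0.10 log units; within the scatter).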

Compound 4, half-maximal cytotoxic concentration: 3330 nM
The estimate for compound 4 lay 2.2-fold (0.35 log units) below the measured number; low and high end bracket the measured number.
By their numbers in this assay, from the lowest: compound 3; then compound 4; then compounds 2 and 1 (each within the scatter of the next).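

Phenyl in place of 1-methylethenyl on the carbonyl carbon gives a 2.8-fold higher number from compound 3 to compound 4 (0.45 log units; beyond the scatter) in this assay, so the group at this spot matters, and not only the arrival of the whole carbamoyl unit. Compound 4 still sits apart from the earlier pair, with a 3.5-fold lower number from compound 2 to compound 4 (0.54 log units; beyond the scatter) and a 3.6-fold lower number from compound 1 to compound 4 (0.55 log units; beyond the scatter), so the lower number is not tied to 1-methylethenyl alone. Nothing available explains these shifts. On these data alone, whether an amine, a carboxylic acid or a longer chain on this carbonyl carbon would raise or lower the number remains open.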